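Swapping an acetoxy chain for a hydroxy chain

The source may report more compounds than this note shows. Statements on the series, on what has been measured and on what is new or still open speak of the compounds shown alone.

Measured in a functional assay on DU-145 cells (Homo sapiens) for cytotoxicity, read by MTT assay; a higher number here means a weaker inhibitor, a lower number a stronger inhibitor:
- Compound 1 `CCCC(O)CC(=O)O[C@H](CC=C(C)C)C1=CC(=O)c2c(O)ccc(O)c2C1=O`: > 100000 nM, a limit of the assay and not a number
- Compound 2 `CC(=O)OCCC(=O)O[C@H](CC=C(C)C)C1=CC(=O)c2c(O)ccc(O)c2C1=O`: 15700 nM
- Compound 3 `CC(=O)OC(C)CO[C@H](CC=C(C)C)C1=CC(=O)c2c(O)ccc(O)c2C1=O`: 16600 nM

Among the compounds with values here, compound 3 cannot be told apart from the only other exact number, as the data show a 1.1-fold higher number from compound 2 to compound 3 (0.02 log units; within the scatter). Both acetoxy compounds differ clearly from the compound that reached the limit, with an at least 6.3-fold lower number from compound 1 to compound 2 (0.80 log units; beyond the scatter).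

The next compound is compound 4 `CCCCC(C)(O)CC(=O)O[C@H](CC=C(C)C)C1=CC(=O)c2c(O)ccc(O)c2C1=O`. It has (2-hydroxy-2-methylhexyl)carbonyl in place of 2-acetoxypropyl on an oxygen on a saturated carbon. Within the data shown here, the nearest precedent is an at least 6.0-fold lower number from compound 1 to compound 3 (0.77 log units; beyond the scatter), where the (2-hydroxypentyl)carbonyl of compound 1 gave way to 2-acetoxypropyl. Compound 4 goes the opposite way, bringing back a hydroxy-bearing chain, so a move toward a higher number in this assay, meaning a weaker inhibitor, is expected. That precedent is a single pair and gives only a bound. Among the measured compounds shown here, no measured compound carries the 2-hydroxy-2-methylhexyl chain, so a full return to the limit is not assumed, though it remains possible. The expected change is a 2.4-fold higher number from compound 3 to compound 4 (0.38 log units; beyond the scatter). For compound 4 the estimated value is 40000 nM, with an expected range from 12000 nM to 100000 nM.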

Compound 4, half-maximal inhibitory concentration: 76500 nM
For compound 4 the middle estimate is 1.9-fold (0.28 log units) below the measured one; measured number inside the range.
By their numbers in this assay, from the lowest: compounds 2 and 3 (each within the scatter of the next); then compound 4. At a limit, above all of these: compound 1.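

Within the data shown here, compound 4 is the first hydroxy-bearing chain here to give an exact number in this assay, so a hydroxy chain on this oxygen does not by itself put a compound at the limit. That chain still sits on the weaker side of both acetoxy compounds, with a 4.6-fold higher number from compound 3 to compound 4 (0.66 log units; beyond the scatter) and with a 4.9-fold higher number from compound 2 to compound 4 (0.69 log units; beyond the scatter). Compound 1 stands at a limit and not a number: the limit of > 100000 nM in this assay, at which 1 of the 4 values shown sits. The data give an at least 1.3-fold lower number from compound 1 to compound 4 (0.11 log units; that floor lies within the scatter), and this step cannot be read as a real difference.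

The swap from 2-acetoxypropyl to (2-hydroxy-2-methylhexyl)carbonyl changes the chain's size and its hydrogen-bond donor count together, so the compounds shown cannot say whether the hydroxy group, the added methyl or the chain length accounts for the step. Going by these compounds, how this position would respond to a chain ending in an amine or a carboxylic acid, or to a hydroxy chain as short as the acetoxy chains, also remains open.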